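The source may report more compounds than this note shows. Statements on the series, on what has been measured and on what is new or still open speak of the compounds shown alone.

In a functional assay on A549 cells (Homo sapiens) for antiproliferative activity, read by MTT assay, with a stated time of 72 h (on this read-out higher numbers stand for weaker inhibition and lower numbers for stronger inhibition), compound 2 `COc1ccc(-c2c(C(=O)c3cc(OC)c(OC)c(OC)c3)sc3ccccc23)c(OC)c1` gives 5800 nM and compound 1 `COc1cc(C(=O)c2sc3ccccc3c2-c2ccc(Cl)cc2)cc(OC)c1OC` gives 7500 nM, so the two stand level within the scatter. Compound 3 `COc1cc(C(=O)c2sc3ccccc3c2Nc2ccc(Cl)cc2)cc(OC)c1OC` follows from compound 2 by one change: (4-chlorophenyl)amino in place of 2,4-dimethoxyphenyl on an aromatic carbon. Going by the values given here, the only measured step at this place, a 1.3-fold lower number from compound 1 to compound 2 (0.11 log units; within the scatter), lies within the scatter, and no amino-linked group has been measured yet. No step beyond the scatter is therefore expected, in either direction, though with wide uncertainty. The estimate amounts to a 1.2-fold lower number from compound 2 to compound 3 (0.06 log units; within the scatter), an expected step. For compound 3 the expected value is 5000 nM, with an estimated range of 1200 nM to 20000 nM.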

Compound 3, half-maximal inhibitory concentration: 3100 nM
The estimate for compound 3 lay 1.6-fold (0.21 log units) above the measured number; measured number inside the range.
By their numbers in this assay, from the lowest: compounds 3, 2 and 1 (each within the scatter of the next, the first and the last beyond it).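

In this assay, going by these compounds alone, the amino link gives the first step beyond the scatter at this position, a 2.4-fold lower number from compound 1 to compound 3 (0.38 log units; beyond the scatter), with the 4-chlorophenyl group kept on the nitrogen. Against 2,4-dimethoxyphenyl the same group gives a 1.9-fold lower number from compound 2 to compound 3 (0.27 log units; within the scatter), so that comparison stays within the scatter. Nothing available accounts for either step.

Open, on these data alone, is whether the amino hydrogen matters, as a methylamino link would show, and whether an ether oxygen in place of the nitrogen behaves alike. Also open, as far as these compounds go, is how 2,4-dimethoxyphenyl behaves when carried on the amino link.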